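Methyl on the amide pyridine: compound 3 to compound 4

The compounds below may be only part of what the source reports. "The series", "measured", "known", "first", "only" and "open" are said of these compounds alone.

In a functional assay on HEK293 cells for negative allosteric modulation of metabotropic glutamate receptor 5 (Rattus norvegicus), read by FLIPR and calcium flux, with a stated time of 170 s (a higher number here means a weaker inhibitor, a lower number a stronger inhibitor), compound 1 `Nc1cccc(COc2cc3n(n2)CCCC3)n1` is recorded as "not active" (no number reported), with no number attached. Compound 2 `N#Cc1ccc(CC(=O)c2cc3n(n2)CCCC3)nc1` gives 53 nM in this assay. Compound 3 `O=C(Nc1ccccn1)c1cc2n(n1)CCCC2` gives 364 nM in this assay, the higher of the two numbers, with the gap to compound 2 beyond the scatter, so compound 3 is the weaker inhibitor of the pair.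

Compound 4 `Cc1cccnc1NC(=O)c1cc2n(n1)CCCC2` differs from compound 3 in one place: methyl in place of hydrogen on an aromatic carbon. Among the measured compounds shown here, no measured pair shows this change, so the series gives no direct guide. In this assay a moderate downward step is expected, estimated as a 2.4-fold lower number from compound 3 to compound 4 (0.39 log units; beyond the scatter). Compound 4 is therefore estimated at 150 nM, with a range from 40 nM to 600 nM.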

Compound 4, half-maximal inhibitory concentration: "not active" (no number reported)
For compound 4 the study gives words and no number, and the estimate cannot be compared.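

Among the compounds shown here, compound 4 carries words and no number, so no step from compound 3 can be read. The compounds shown leave open what step methyl in place of hydrogen gives between two numbered compounds. No measurement shown bears on this result.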